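Swapping a Side Group When Only a Limit Is Known

A few compounds are considered here, and "the series" means these few. Any claim that something is new, unique, unknown or untested is made for them only; others in the source may bear on it.

In a functional assay on HCT-116 cells (Homo sapiens) for antiproliferative activity, read by MTT assay, with a stated time of 24 h (a lower number here means a stronger inhibitor, a higher number a weaker inhibitor), compound 1 (`C=CCOc1ccc2c(=O)c(-c3cc(OC)c(OC)cc3OC)coc2c1`) gives 6600 nM as its reading. Compound 2 (`COc1cc(OC)c(-c2coc3cc(OCC(=O)c4cccc(C(F)(F)F)c4)ccc3c2=O)cc1OC`) stands at > 10000 nM and this value is a limit. For the measured compounds named here, the only measured step at this place is an at least 1.5-fold higher number from compound 1 to compound 2 (0.18 log units; that floor lies within the scatter) and it stays within the scatter. Compound 3 (`COc1cc(OC)c(-c2coc3cc(OCc4ccccc4F)ccc3c2=O)cc1OC`) has 2-fluorophenyl in place of (3-(trifluoromethyl)phenyl)carbonyl on a saturated chain carbon bound to an oxygen on an aromatic ring. No change beyond the scatter is expected in this assay and the estimated step is an at least 1.2-fold lower number from compound 2 to compound 3 (0.09 log units; that floor lies within the scatter) for now. Compound 3 is estimated at 8000 nM (range 3000 nM to 20000 nM).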

Compound 3, half-maximal inhibitory concentration: 2900 nM
The estimate for compound 3 lay 2.8-fold (0.44 log units) above the measured number, outside the stated range (below it).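

Unlike the earlier step, which stayed within the scatter, these results show that the side group at this position can move the reading in this assay: 2-fluorophenyl in place of (3-(trifluoromethyl)phenyl)carbonyl gives an at least 3.4-fold lower number from compound 2 to compound 3 (0.53 log units; beyond the scatter). In place of vinyl, the same group gives a 2.3-fold lower number from compound 1 to compound 3 (0.36 log units; beyond the scatter). Compound 2 is read only as a limit, so its step gives a floor and not a full size: the limit of > 10000 nM in this assay, at which 1 of the 3 values shown sits.

The compounds shown leave open whether the fluorine itself matters, since plain phenyl does not appear among them. They also leave open how an amine or a carboxylic acid on this chain would read.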